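Cyano substitution on the core of the acrylamide series

The compounds below may be only part of what the source reports. "The series", "measured", "known", "first", "only" and "open" are said of these compounds alone.

Measured compounds:
compound 1 `C=CC(=O)Nc1cc(Nc2nccc(-c3cn(C)c4ccc(F)cc34)n2)c(OC)cc1N(C)CCN(C)C`, 254 nM
compound 2 `CC/C=C\C(=O)Nc1cc(Nc2nccc(-c3cn(C)c4ccc(F)cc34)n2)c(OC)cc1N(C)CCN(C)C`, 2600 nM
compound 3 `CCC/C=C\C(=O)Nc1cc(Nc2nccc(-c3cn(C)c4ccc(F)cc34)n2)c(OC)cc1N(C)CCN(C)C`, 2730 nM

In a functional assay on NCI-H1975 cells (Homo sapiens) for antiproliferative activity, read by MTT assay, with a stated time of 72 h (on this read-out higher numbers stand for weaker inhibition and lower numbers for stronger inhibition), compound 1 gives the lowest number of the three and is the most potent member, as its steps to both other compounds lie beyond the scatter. Lengthening the acrylamide chain costs activity: a 10-fold higher number from compound 1 to compound 2 (1.01 log units; beyond the scatter) and an 11-fold higher number from compound 1 to compound 3 (1.03 log units; beyond the scatter) are both large, while a 1.1-fold higher number from compound 2 to compound 3 (0.02 log units; within the scatter) shows that the two longer chains are indistinguishable.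

Compound 4 `C=CC(=O)Nc1cc(Nc2ncc(C#N)c(-c3cn(C)c4ccc(F)cc34)n2)c(OC)cc1N(C)CCN(C)C` keeps the acrylamide of compound 1 unchanged and alters the core instead: cyano in place of hydrogen on an aromatic carbon. Within the data shown here, no measured step bears on this position; the three steps known all concern the chain on the carbonyl carbon, so they give no direct guide to a substituent on the six-membered aromatic ring with two nitrogens. The estimate therefore rests on compound 1 alone, with 254 nM as the anchor and a wide range to cover an unknown position, and no shift beyond the scatter is expected in either direction.

For compound 4 the expected value in this assay is 220 nM, with a range from 60 nM to 800 nM. This corresponds to an expected step of a 1.2-fold lower number from compound 1 to compound 4 (0.06 log units; within the scatter).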

Compound 4, half-maximal inhibitory concentration: 11400 nM
Compound 4: the middle estimate sits 52-fold (1.71 log units) below what was measured; the measured number lies above the stated range.
By their numbers in this assay, from the lowest: compound 1; then compounds 2 and 3 (each within the scatter of the next); then compound 4.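

The aromatic carbon ortho to the 5-fluoro-1-methyl-1H-indol-3-yl group proves to be a sensitive point on the shared core: in this assay, cyano in place of hydrogen gives a 45-fold higher number from compound 1 to compound 4 (1.65 log units; beyond the scatter), although the entering group has only 2 heavy atoms. The acrylamide is unchanged in this pair, so the loss belongs to the core change alone, and the step is larger than the one seen on the chain, a 10-fold higher number from compound 1 to compound 2 (1.01 log units; beyond the scatter). The series therefore loses activity through a single substitution on the core as well as through chain lengthening, and nothing at hand accounts for the size of this loss.

With one substituent at this position, the compounds shown cannot tell whether the loss is particular to cyano or would also follow from a fluorine atom, a chlorine atom, a methyl group or an amine on the same carbon. Also open, on these data alone, is how cyano at this position behaves alongside the but-1-en-1-yl or pent-1-en-1-yl chain of compound 2 or compound 3.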